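A few compounds are considered here, and "the series" means these few. Any claim that something is new, unique, unknown or untested is made for them only; others in the source may bear on it.

In a functional assay on the whole organism (Hindlimb, strain albino) with Mus musculus as the target, in the maximal electroshock model, with a stated time of 0.5 h (on this read-out higher numbers stand for an effect only at larger amounts of compound and lower numbers for an effect already at smaller amounts), compound 3 (`CC(=O)N1N=C(Nc2nc3ccc([N+](=O)[O-])cc3s2)CC1c1ccc(Cl)cc1`) gives 132 umol/kg and sits within the scatter of compound 1 (`COc1ccc(C2CC(Nc3nc4ccc([N+](=O)[O-])cc4s3)=NN2C(C)=O)cc1O`) at 178 umol/kg while compound 2 (`CC(=O)N1N=C(Nc2nc3ccc(C)cc3s2)CC1c1ccc(Cl)cc1`) at 25.5 umol/kg lies lower, beyond the scatter. Compound 4 (`CC(=O)N1N=C(Nc2nc3ccc(Cl)cc3s2)CC1c1ccc(Cl)cc1`) has chloro in place of nitro on an aromatic carbon. The closest guide is the other step involving nitro on an aromatic carbon, nitro in place of methyl (a 5.2-fold higher number from compound 2 to compound 3 (0.71 log units; beyond the scatter)), which is modest but beyond the scatter. The step on the saturated ring carbon (a 1.3-fold lower number from compound 1 to compound 3 (0.13 log units; within the scatter)) stays within the scatter and concerns another place, so it adds little. Among the compounds with values here, no chloro compound has yet been measured at this place, which leaves the size uncertain. A modest step toward a lower number is therefore expected in this assay and the estimated step is (a 2.9-fold lower number from compound 3 to compound 4 (0.47 log units; beyond the scatter)). Compound 4 is estimated at 45 umol/kg (expected range 15 umol/kg to 130 umol/kg).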

Compound 4, dose for half-maximal effect: 79.5 umol/kg
Estimate against measurement, compound 4: 1.8-fold (0.25 log units) below, and the stated range covers the measured number.
By their numbers in this assay, from the lowest: compound 2; then compounds 4, 3 and 1 (each within the scatter of the next, the first and the last beyond it).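

In this assay, exchanging nitro (3 heavy atoms, 2 hydrogen-bond acceptors) for chloro (1 heavy atom, 0 hydrogen-bond acceptors) on this aromatic carbon leaves the two compounds inseparable (a 1.7-fold lower number from compound 3 to compound 4 (0.22 log units; within the scatter)), so the earlier gap between the methyl and nitro compounds does not mark nitro alone as the outlier. Methyl now stands apart from chloro as well (a 3.1-fold higher number from compound 2 to compound 4 (0.49 log units; beyond the scatter)), which makes compound 2 the only one of these three compounds, all carrying 4-chlorophenyl, that is separated from the others beyond the scatter. No measured evidence available here accounts for this separation.

On these data alone, it remains open whether methyl is a special case at this place or whether ethyl, methoxy or an amine would fall with it. As far as these compounds go, whether methyl keeps its separation from nitro alongside the 3-hydroxy-4-methoxyphenyl of compound 1 also remains open.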